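The source may hold more compounds than are shown below. What is called first, only, known or untested is meant among the compounds shown, and "the series" means these compounds.

Compound 3 `CN(C)CCn1cnnc1-c1cc(Oc2ccc(NC(=O)N/N=C/c3cc(Br)c(O)c(Br)c3)cc2F)ccn1` gives 2670 nM in a functional assay on HT-29 cells (Homo sapiens) for cytotoxicity, read by MTT assay, with a stated time of 72 h (on this read-out lower numbers stand for stronger inhibition and higher numbers for weaker inhibition), the highest of the three numbers measured; compound 1 `CN(C)CCn1cnnc1-c1cc(Oc2ccc(NC(=O)N/N=C/c3c(Cl)cccc3Cl)cc2F)ccn1` gives 280 nM and compound 2 `CN(C)CCn1cnnc1-c1cc(Oc2ccc(NC(=O)N/N=C/c3cccc(Cl)c3Cl)cc2F)ccn1` gives 130 nM in this assay. Two steps lead to compound 3: a 9.5-fold higher number from compound 1 to compound 3 (0.98 log units; beyond the scatter) and a 21-fold higher number from compound 2 to compound 3 (1.31 log units; beyond the scatter), both well beyond the scatter, while a 2.2-fold lower number from compound 1 to compound 2 (0.33 log units; beyond the scatter) is a smaller change between the two dichlorophenyl compounds. Compound 4 `CN(C)CCn1cnnc1-c1cc(Oc2ccc(NC(=O)N/N=C/c3ccc(O)c(F)c3)cc2F)ccn1` differs from compound 3 in one place: 3-fluoro-4-hydroxyphenyl in place of 3,5-dibromo-4-hydroxyphenyl on a carbon with a double bond to nitrogen. Going by the values given here, no measured step swaps one hydroxyphenyl variant for another, so no direct precedent exists; the measured steps show only that the hydroxyphenyl compound 3 sits far above the two dichlorophenyl compounds. Compound 4 keeps the hydroxyl and carries one fluorine in place of two bromines, so a step of uncertain direction is expected, most likely a modest move toward a lower number but possibly none beyond the scatter, giving the estimate a 1.8-fold lower number from compound 3 to compound 4 (0.25 log units; within the scatter). Compound 4 is therefore expected to give about 1500 nM in this assay, between 400 nM and 6000 nM.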

Compound 4, half-maximal inhibitory concentration: 3310 nM
Compound 4: the middle estimate sits 2.2-fold (0.34 log units) below what was measured, within the range that was stated.
By their numbers in this assay, from the lowest: compound 2; then compound 1; then compounds 3 and 4 (each within the scatter of the next).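

Set side by side in this assay, the two hydroxyphenyl groups on the carbon with a double bond to nitrogen give a 1.2-fold higher number from compound 3 to compound 4 (0.09 log units; within the scatter) and so cannot be told apart here, although one carries two bromines and the other one fluorine. The gap to the dichlorophenyl compounds recurs with this second hydroxyphenyl group, as a 25-fold higher number from compound 2 to compound 4 (1.41 log units; beyond the scatter) and a 12-fold higher number from compound 1 to compound 4 (1.07 log units; beyond the scatter) show, and none of the four compounds goes against this split. Nothing available explains the gap between the two kinds of group.

From the compounds shown here alone, whether the hydroxyl itself goes with the higher numbers remains open, and a methoxy group or an amine in its place would bear on that. So does whether a 3-fluorophenyl group without the hydroxyl would stay with the hydroxyphenyl compounds or the dichlorophenyl ones.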